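A few compounds are considered here, and "the series" means these few. Any claim that something is new, unique, unknown or untested is made for them only; others in the source may bear on it.

Measured so far in an assay on isolated protein for displacement of a labelled ligand from 5-hydroxytryptamine receptor 6 (Homo sapiens); on this read-out higher numbers stand for weaker inhibition and lower numbers for stronger inhibition:
compound 1 `O=S(=O)(c1cccc(F)c1)c1ccc2c(c1)CCC[C@H]2CN1CCCS1(=O)=O` gives 31.6 nM
compound 2 `N=C(N)NC(=O)C[C@@H]1CCCc2cc(S(=O)(=O)c3cccc(F)c3)ccc21` gives 0.631 nM
compound 3 `CNC(=O)NC[C@@H]1CCCc2cc(S(=O)(=O)c3cccc(F)c3)ccc21` gives 0.398 nM

Compound 1 stands highest of the three numbers in this assay. Its nearest neighbour is compound 2, reached by a 50-fold lower number from compound 1 to compound 2 (1.70 log units; beyond the scatter); the furthest is compound 3, reached by a 79-fold lower number from compound 1 to compound 3 (1.90 log units; beyond the scatter). Between compound 2 and compound 3 the difference is a 1.6-fold lower number from compound 2 to compound 3 (0.20 log units; within the scatter).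

Compound 4 `CS(=O)(=O)NC[C@@H]1CCCc2cc(S(=O)(=O)c3cccc(F)c3)ccc21` is not yet measured. Relative to compound 1 the change is a group of 5 heavy atoms (1 carbon, 1 nitrogen, 2 oxygen, 1 sulfur; no ring) in place of a group of 7 heavy atoms (3 carbon, 1 nitrogen, 2 oxygen, 1 sulfur; one five-membered non-aromatic ring with 2 hetero atoms), on a saturated chain carbon bound to a saturated ring carbon. The two measured steps from compound 1, to compound 2 and to compound 3, bear on it: each exchanges the same five-membered ring for an open-chain group on the same saturated chain carbon, and each is a large lowering in this assay. The entering methanesulfonamido is likewise open-chain, so a lowering in the same direction is expected. Its exact size is less certain, as neither compound 2 nor compound 3 carries a sulfonamide, and the estimate is placed a little short of those two steps. Compound 4 is therefore expected to give about 2 nM, within 0.5 nM to 8 nM. This corresponds to an expected step of a 16-fold lower number from compound 1 to compound 4 (1.20 log units; beyond the scatter).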

Compound 4, inhibition constant: 0.2 nM
Estimate against measurement, compound 4: 10-fold (1.00 log units) above, outside the stated range (below it).
By their numbers in this assay, from the lowest: compounds 4, 3 and 2 (each within the scatter of the next, the first and the last beyond it); then compound 1.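

In this assay, methanesulfonamido in place of the five-membered ring on the saturated chain carbon gives a 160-fold lower number from compound 1 to compound 4 (2.20 log units; beyond the scatter), so a sulfonamide also fits the open-chain trend set by compound 2 and compound 3, with the ring gone and a hydrogen-bond donor present. Methylsulfonyl in place of methylcarbamoyl on the amine nitrogen gives a 2.0-fold lower number from compound 3 to compound 4 (0.30 log units; within the scatter), so that exchange is not resolved in this assay, whereas the change from the group of compound 2 gives a 3.2-fold lower number from compound 2 to compound 4 (0.50 log units; beyond the scatter). Nothing shown accounts for any of these steps.

The compounds shown leave open whether loss of the ring or presence of the amide hydrogen separates compound 1 from compound 4, a question that an N-methyl methanesulfonamido group would address. From the compounds shown here alone, how far this position accepts larger sulfonyl groups, such as ethylsulfonyl or phenylsulfonyl, also remains open.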